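Removing the Azetidine Hydroxy Group from Compound 1

The compounds below may be only part of what the source reports. "The series", "measured", "known", "first", "only" and "open" are said of these compounds alone.

Measured compounds:
- compound 1, `Cc1c(C(=O)O)c(-c2cccc(N3CCN(c4ccc(NS(=O)(=O)c5ccc(N[C@H](CCN6CC(O)C6)CSc6ccccc6)c(S(=O)(=O)C(F)(F)F)c5)cc4)CC3)c2)c(-c2ccc(Cl)cc2)n1C`: 299 nM
- compound 2, `CCn1c(C)c(C(=O)O)c(-c2cccc(N3CCN(c4ccc(NS(=O)(=O)c5ccc(N[C@H](CCN6CCC(O)CC6)CSc6ccccc6)c(S(=O)(=O)C(F)(F)F)c5)cc4)CC3)c2)c1-c1ccc(Cl)cc1`: 21 nM

Within the data shown here, in a functional assay on NCI-H1417 cells (Homo sapiens) for inhibition, read by WST assay, with a stated time of 4 days (a lower number here means a stronger inhibitor, a higher number a weaker inhibitor), compound 1 gives 299 nM, the higher of the two numbers measured so far. Among the measured compounds shown here, compound 2 differs from it in more than one place, so no single step can be drawn between them; their two values simply show that compound 2 sits far lower, with a gap beyond the usual scatter. Compound 3, `Cc1c(C(=O)O)c(-c2cccc(N3CCN(c4ccc(NS(=O)(=O)c5ccc(N[C@H](CCN6CCC6)CSc6ccccc6)c(S(=O)(=O)C(F)(F)F)c5)cc4)CC3)c2)c(-c2ccc(Cl)cc2)n1C`, has not yet been measured. It is reached from compound 1 by a single change, (hydrogen in place of hydroxy on a saturated ring carbon), that is, hydrogen in place of hydroxy on a saturated ring carbon. For the measured compounds named here, nothing among the measured compounds isolates this change, so the expectation rests on its small size alone. For compound 3 the step of a 1.2-fold higher number from compound 1 to compound 3 (0.08 log units; within the scatter) is expected to stay within the scatter, with at most a slight drift toward a weaker inhibitor. In this assay compound 3 is therefore estimated at 360 nM, within a range from 120 nM to 1100 nM.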

Compound 3, half-maximal inhibitory concentration: 126 nM
For compound 3 the middle estimate is 2.9-fold (0.46 log units) above the measured one; the range from low to high includes it.
By their numbers in this assay, from the lowest: compound 2; then compound 3; then compound 1.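

Going from 3-hydroxyazetidin-1-yl to azetidin-1-yl gives a 2.4-fold lower number from compound 1 to compound 3 (0.38 log units; beyond the scatter) in this assay, the first reading of a single change at this position. Though modest, the step lies beyond the scatter and runs toward a stronger inhibitor, so in this pair the hydroxy on the saturated ring carbon, two ring bonds from the ring nitrogen, is not needed for inhibition in these cells, and compound 3 keeps its activity with hydrogen in that place. No measurement at hand accounts for the direction of this step.

A single pair cannot tell whether another small group on the same ring carbon, such as a fluorine atom, a methoxy group or an amine, would follow hydrogen or stay closer to hydroxy. Compound 2 differs from compound 3 in more than one place, so the compounds shown also leave open how much of its lower number belongs to the amine ring and how much to the other changes.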